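A fluoro for a methyl, measured at the limit

A few compounds are considered here, and "the series" means these few. Any claim that something is new, unique, unknown or untested is made for them only; others in the source may bear on it.

Compound 1, `Cc1ccccc1-n1nncc1CN1C(=O)C2(C(C#N)=C(N)Oc3c2c2nc4ccccc4nc2c2ccccc32)c2ccccc21`, gives in an ADME assay on L02 cells (Homo sapiens) for antiproliferative activity, read by MTT assay, with a stated time of 48 h (on this read-out lower numbers stand for stronger inhibition and higher numbers for weaker inhibition), only a limit, > 50000 nM.
Compound 2, `Cc1ccc(-n2nncc2CN2C(=O)C3(C(C#N)=C(N)Oc4c3c3nc5ccccc5nc3c3ccccc43)c3ccccc32)cc1Cl`, gives in this assay only a limit, > 50000 nM.

Going by the values given here, compound 2 therefore stands at the limit of this assay, and the one further value shown is a limit too, so its place among the numbers cannot be read more finely. Among the compounds with values here, the single measured step, a step that the two limits leave unreadable from compound 1 to compound 2, is a step that the two limits leave unreadable. Within the data shown here, the only evidence is the limit of > 50000 nM in this assay, at which 2 of the 2 values shown sit.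

Compound 3, `N#CC1=C(N)Oc2c(c3nc4ccccc4nc3c3ccccc23)C12C(=O)N(Cc1cnnn1-c1ccc(F)c(Cl)c1)c1ccccc12`, differs from compound 2 by fluoro in place of methyl on an aromatic carbon. No measured step bears on this change, because the one step shown, a step that the two limits leave unreadable from compound 1 to compound 2, has no readable size. The expectation for compound 3 in this assay is therefore a step that the limit leaves unreadable from compound 2 to compound 3, with no direction beyond the scatter. Compound 3 is expected at 60000 nM, in the range 25000 nM to 150000 nM, most likely again only as a limit.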

Compound 3, half-maximal inhibitory concentration: > 50000 nM
Compound 3 ended at the assay's limit; the forecaster's own chance of this, stated with the estimate: 85%; the middle value lies beyond the limit too.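

Compound 1, compound 2 and compound 3 each give only a limit in this assay, so no step among them can be read: the limit of > 50000 nM in this assay, at which 3 of the 3 values shown sit.

From the compounds shown here alone, the true values of these three compounds stay open, and with them whether fluoro in place of methyl changes the inhibition at all.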